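Methoxy for chloro on a thiazole amide: expected solubility

This account rests on a few compounds, and the source may have more. Where it says the series, first, only, none or still open, it means among the compounds named here.

Three amides on a shared core have been measured in a physicochemical assay for solubility, read by nephelometry, measured as kinetic solubility, at pH 6.5; a lower number here means a less soluble compound, a higher number a more soluble compound. Compound 1 `NCc1csc(NC(=O)c2ccc(Cl)cc2)n1` gives 25 ug/mL, the higher of the two numbers recorded. Compound 3 `NCc1csc(NC(=O)c2cc3ccccc3n2Cc2ccccc2)n1` gives 1.6 ug/mL, a step beyond the scatter below compound 1. Compound 2 `NCc1csc(NC(=O)c2ncccn2)n1` returns no number but only a limit, > 100 ug/mL, which is the limit of > 100 ug/mL in this assay, at which 1 of the 3 values shown sits. Compound 4 `COc1ccc(C(=O)Nc2nc(CN)cs2)cc1` has not yet been measured in this assay; compared with compound 1 it differs by methoxy in place of chloro on an aromatic carbon. Within the data shown here, no measured pair shows this change, so the expected step of a 1.6-fold higher number from compound 1 to compound 4 (0.20 log units; within the scatter) is a small rise in solubility, plausibly within the scatter. Compound 4 is therefore estimated at 40 ug/mL, with a range from 15 ug/mL to 100 ug/mL.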

Compound 4, solubility: 25 ug/mL
Estimate against measurement, compound 4: 1.6-fold (0.20 log units) above, within the range that was stated.
By their numbers in this assay, from the lowest: compound 3; then compounds 1 and 4 (each within the scatter of the next). At a limit, above all of these: compound 2.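

Methoxy in place of chloro on an aromatic carbon, para to a large group, gave no change at the digits printed from compound 1 to compound 4 (within the scatter) in this assay, the first direct reading of this change on the shared core. Among these compounds, compounds 1 and 4 differ in this one place only, and the earlier compounds held no such pair. Nothing measured here accounts for this result.

On these data alone, whether an amine or a carboxylic acid in this same place would move the number remains open. So does whether methoxy for chloro would read the same on another amide.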